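Propyl to butyl on the shared core

The source may hold more compounds than are shown below. What is called first, only, known or untested is meant among the compounds shown, and "the series" means these compounds.

Measured so far:
compound 1, `CCCNC(=O)Nc1cc2nc(C3CCCCC3)[nH]c2cc1N(CC)CC`: > 100 ug/mL
compound 2, `CCCCOC(=O)Nc1cc2nc(C3CCCCC3)[nH]c2cc1N(CC)CCN(CC)CC`: > 50 ug/mL

Compound 1 carries the shared core with a propyl chain on the amide-type nitrogen. In an ADME assay on Vero cells (Chlorocebus sabaeus) for cytotoxicity, read by resazurin assay, with a stated time of 3 days (a higher number here means a weaker inhibitor, a lower number a stronger inhibitor), compound 1 reaches only a limit, > 100 ug/mL, and no number. Compound 2 in this assay likewise stops at a limit, > 50 ug/mL. Both readings are limits the limit of > 100 ug/mL in this assay, at which 1 of the 2 values shown sits, and (the limit of > 50 ug/mL in this assay, at which 1 of the 2 values shown sits), so compound 1 cannot be ranked against compound 2 and stands only at the top end of what this assay reports.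

Compound 3, `CCCCNC(=O)Nc1cc2nc(C3CCCCC3)[nH]c2cc1N(CC)CC`, differs from compound 1 in one place: methyl in place of hydrogen on a saturated chain carbon, three bonds along the chain from an amide-type nitrogen. Going by the values given here, no measured pair shows a step of this kind, so no measured size can be carried over. In this assay the step is expected to be none beyond the scatter, with compound 1 already at a limit. For compound 3 the estimate is 120 ug/mL with a range of 50 ug/mL to 300 ug/mL, which means an expected step that the limit leaves unreadable from compound 1 to compound 3.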

Compound 3, half-maximal inhibitory concentration: > 100 ug/mL
Compound 3: only a limit was reported; the forecaster's own chance of this, stated with the estimate: 85%; the middle value lies beyond the limit too.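

In this assay compound 3 gives only a limit, > 100 ug/mL. Compound 1 also gives only a limit, > 100 ug/mL, so no step can be read from compound 1 to compound 3. The compounds shown leave open how large the propyl to butyl change is in this assay, and whether it has any size there at all.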